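Swapping benzyl for an aryl group on the aromatic nitrogen

The compounds below may be only part of what the source reports. "The series", "measured", "known", "first", "only" and "open" are said of these compounds alone.

Measured in a functional assay on HT-29 cells (Homo sapiens) for antiproliferative activity, read by MTT assay, with a stated time of 72 h; on this read-out lower numbers stand for stronger inhibition and higher numbers for weaker inhibition:
compound 1 `COc1cc(-c2nccn2CC(C)C)cc(OC)c1OC`: > 100000 nM (a limit)
compound 2 `COc1cc(-c2nccn2Cc2ccccc2)cc(OC)c1OC`: > 100000 nM (a limit)

Compound 2 gives > 100000 nM in this assay, which is a limit and not a number. Both measured compounds share this position: the limit of > 100000 nM in this assay, at which 2 of the 2 values shown sit. Compound 3 `COc1cc(-c2nccn2-c2cccc(C)c2)cc(OC)c1OC` carries 3-methylphenyl in place of benzyl on an aromatic nitrogen. Among the measured compounds shown here, the only measured step with a bearing on this is a step that the two limits leave unreadable from compound 1 to compound 2, and it gives no size to carry over. Weak inhibition in this assay is therefore expected to persist, with only a small gain, if any. The estimated step is an at least 2.0-fold lower number from compound 2 to compound 3 (0.30 log units; that floor lies within the scatter). For compound 3 the estimated value is 50000 nM, with an expected range of 10000 nM to 100000 nM.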

Compound 3, half-maximal inhibitory concentration: 14600 nM
The estimate for compound 3 lay 3.4-fold (0.53 log units) above the measured number; the measured number falls inside the stated range.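

In this assay, among the compounds shown here, an aryl group directly on the aromatic nitrogen gives the first readable number of the series: 3-methylphenyl in place of benzyl gives an at least 6.8-fold lower number from compound 2 to compound 3 (0.83 log units; beyond the scatter) and 3-methylphenyl in place of isobutyl gives an at least 6.8-fold lower number from compound 1 to compound 3 (0.83 log units; beyond the scatter) on the same read-out. The step between the two earlier compounds cannot be read, and compound 3 alone stands clear of the limit: the limit of > 100000 nM in this assay, at which 2 of the 3 values shown sit.

Open, from the compounds shown here alone, is whether the methyl group matters, which plain phenyl on the same nitrogen would test. Also open, going by these compounds, is how 3-aminophenyl or 3-carboxyphenyl there would compare.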